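This account rests on a few compounds, and the source may have more. Where it says the series, first, only, none or still open, it means among the compounds named here.

Measured compounds:
compound 1, `C/C=C/C(=O)N(Cc1cccc(O)c1)c1cc(OC)c(OC)c(OC)c1`, 14700 nM
compound 2, `C/C=C/C(=O)N(Cc1ccc(OC)c(C)c1)c1cc(OC)c(OC)c(OC)c1`, 32900 nM
compound 3, `COc1ccc(CNc2cc(OC)c(OC)c(OC)c2)cc1Br`, 39800 nM

All three were tested in a functional assay on KYSE-450 cells (Homo sapiens) for inhibition, read by MTT assay, with a stated time of 48 h; a lower number here means a stronger inhibitor, a higher number a weaker inhibitor. Compound 3 gives the highest number of the three; its nearest neighbour is compound 2, whose value stands within the scatter of that of compound 3, while compound 1 sits furthest off, beyond the scatter. The unmeasured compound 4, `C/C=C/C(=O)N(Cc1ccc(OC)c(Br)c1)c1cc(OC)c(OC)c(OC)c1`, is reached from compound 3 by one change: (prop-1-en-1-yl)carbonyl in place of hydrogen on a nitrogen on an aromatic ring. Among the compounds with values here, no measured pair shares this change, so no step speaks to it directly. Within the data shown here, the single measured step, a 2.2-fold higher number from compound 1 to compound 2 (0.35 log units; beyond the scatter), concerns a different part of the molecule, a swap of one aryl group for another, and is modest. Compound 4 carries the same (prop-1-en-1-yl)carbonyl as compounds 1 and 2, and its nearest measured relative by structure is compound 2, with which compound 3 already agrees within the scatter. Compound 4 is therefore expected to give a number close to that of compound 2, and the step of a 1.3-fold lower number from compound 3 to compound 4 (0.12 log units; within the scatter) is expected to stay within the scatter. For compound 4 the estimate in this assay is 30000 nM, with a range from 12000 nM to 80000 nM.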

Compound 4, half-maximal inhibitory concentration: 10500 nM
Estimate against measurement, compound 4: 2.9-fold (0.46 log units) above; measured number outside the range, below it.
By their numbers in this assay, from the lowest: compounds 4 and 1 (each within the scatter of the next); then compounds 2 and 3 (each within the scatter of the next).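

In this assay, within the data shown here, (prop-1-en-1-yl)carbonyl in place of hydrogen on the nitrogen gives a 3.8-fold lower number from compound 3 to compound 4 (0.58 log units; beyond the scatter) and is the first direct reading of this position: with the 3-bromo-4-methoxyphenyl group held fixed, the group on this nitrogen moves the number beyond the scatter. With that carbonyl group in place, the aryl group also matters, though not for every swap: bromo in place of methyl on an aromatic carbon gives a 3.1-fold lower number from compound 2 to compound 4 (0.50 log units; beyond the scatter), while 3-bromo-4-methoxyphenyl in place of 3-hydroxyphenyl gives a 1.4-fold lower number from compound 1 to compound 4 (0.15 log units; within the scatter). Nothing shown here accounts for these steps. As far as these compounds go, whether acetyl or a longer acyl chain on that nitrogen would move the number as (prop-1-en-1-yl)carbonyl does remains open. So does whether the same change would hold with the 3-hydroxyphenyl or 4-methoxy-3-methylphenyl groups.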